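From imidazole to hydroxy on the chain of compound 3

A few compounds are considered here, and "the series" means these few. Any claim that something is new, unique, unknown or untested is made for them only; others in the source may bear on it.

In a functional assay on SMMC-7721 cells (Homo sapiens) for antiproliferative activity, read by MTT assay, with a stated time of 48 h (on this read-out lower numbers stand for stronger inhibition and higher numbers for weaker inhibition), compound 1 (`CN1CCN(CCCn2nc(C3=C(c4cn(C)c5ccccc45)C(=O)NC3=O)c3cccnc32)CC1`) gives > 100000 nM as a limit of the assay, not a number. Compound 2 (`CN(C)CCCn1nc(C2=C(c3cn(C)c4ccccc34)C(=O)NC2=O)c2cccnc21`) likewise gives > 100000 nM as a limit of the assay. Within the data shown here, compound 3 (`Cn1cc(C2=C(c3nn(CCCCn4ccnc4)c4ncccc34)C(=O)NC2=O)c2ccccc21`) gives 29200 nM as the only true number so far, so it has no measured neighbour to be ranked against precisely.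

Compound 4 (`Cn1cc(C2=C(c3nn(CCCO)c4ncccc34)C(=O)NC2=O)c2ccccc21`) keeps the shared core but has hydroxy in place of (1H-imidazol-1-yl)methyl on a saturated chain carbon, three bonds along the chain from an aromatic nitrogen. Two measured steps changed the same place. Putting (1H-imidazol-1-yl)methyl in place of 4-methylpiperazin-1-yl gave an at least 3.4-fold lower number from compound 1 to compound 3 (0.53 log units; beyond the scatter) as its result, and putting it in place of dimethylamino gave an at least 3.4-fold lower number from compound 2 to compound 3 (0.53 log units; beyond the scatter) as its result. Both are lower bounds, and both favour the imidazole-bearing compound 3.

Compound 4 gives that group up, so the number is expected to move back upward, towards weaker inhibition, although hydroxy itself has not been tested here. In this assay a modest rise is expected, with a 2.4-fold higher number from compound 3 to compound 4 (0.38 log units; beyond the scatter) as the estimated step. For compound 4 the estimate is 70000 nM with an expected range of 25000 nM to 100000 nM as its span.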

Compound 4, half-maximal inhibitory concentration: > 100000 nM
Compound 4: no number, only a limit; the forecaster's own chance of this, stated with the estimate: 45%; middle value at least 1.4-fold (0.15 log units) from the limit.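

In this assay, hydroxy in place of (1H-imidazol-1-yl)methyl, on a saturated chain carbon three bonds along the chain from an aromatic nitrogen, gives an at least 3.4-fold higher number from compound 3 to compound 4 (0.53 log units; beyond the scatter). Among the four compounds, three different end groups (4-methylpiperazin-1-yl, dimethylamino and hydroxy) now fall short of the imidazole-bearing compound 3, which is the only one with a true number, and hydroxy shows that this holds for an end group with no nitrogen and no ring as well. The steps among compound 1, compound 2 and compound 4 cannot be read, because each of these compounds gives only a limit, not a number: the limit of > 100000 nM in this assay, at which 3 of the 4 values shown sit.

Cut one bond further out, the change also reads 4-(1H-imidazol-1-yl)butyl to 3-hydroxypropyl, so it leaves open whether the imidazole ring or the longer chain matters, and a 4-hydroxybutyl or a 3-(1H-imidazol-1-yl)propyl chain would separate the two. Also open, from the compounds shown here alone, is how other end groups would compare with imidazole at this place, such as a 1,2,4-triazole ring, a primary amine or a carboxylic acid.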